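A few compounds are considered here, and "the series" means these few. Any claim that something is new, unique, unknown or untested is made for them only; others in the source may bear on it.

Compound 1 `CCOc1ccc(-c2cc(C3CC(C)(C)OC(C)(C)C3)nn2-c2ccccc2OC)cc1` was tested in an assay on HEK293 cells for inhibition of Voltage-dependent N-type calcium channel subunit alpha-1B (Homo sapiens), read by patch clamp, using a membrane potential dye (on this read-out higher numbers stand for weaker inhibition and lower numbers for stronger inhibition), where compound 1 gives 29 nM. Among the three compounds measured so far, this number is the second highest. Compound 2 `COc1ccccc1-n1nc([C@H]2C[C@@H](C)O[C@@H](C)C2)cc1-c1ccc(Cl)cc1` gives 12 nM in this assay, a lower number than compound 1 by a gap beyond the usual scatter. Compound 3 `CC1(C)CC(c2cc(-c3ccc(Cl)cc3)n(-c3ccccn3)n2)CC(C)(C)O1` gives 1000 nM in this assay, the highest of the three and well beyond the scatter from compound 1.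

Compound 4 `COc1ccccc1-n1nc(C2CC(C)(C)OC(C)(C)C2)cc1-c1ccc(C#N)cc1` has not yet been measured. It differs from compound 1 in one place: cyano in place of ethoxy on an aromatic carbon. Going by the values given here, no measured pair among the three compounds shows this same change, so the size of the step cannot be read from the data. The expected step in this assay is a 1.7-fold higher number from compound 1 to compound 4 (0.24 log units; within the scatter), a modest move toward a higher number, probably a little beyond the scatter. For compound 4 the estimated value in this assay is 50 nM, with a range from 15 nM to 170 nM.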

Compound 4, half-maximal inhibitory concentration: 85 nM
Estimate against measurement, compound 4: 1.7-fold (0.23 log units) below; the measured number falls inside the stated range.
By their numbers in this assay, from the lowest: compound 2; then compound 1; then compound 4; then compound 3.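

In this assay, going by these compounds alone, the 4-ethoxyphenyl to 4-cyanophenyl change gives the first single-place reading at this aromatic carbon, para to a large group, with a 2.9-fold higher number from compound 1 to compound 4 (0.47 log units; beyond the scatter). The step lies beyond the usual scatter, so this position does respond to the choice of group, yet the size of the step is modest and the nitrile keeps compound 4 within the measurable range of the assay. Nothing shown here accounts for why the cyano compound gives the higher number.

The compounds shown leave open whether a longer chain such as propoxy, an amine such as dimethylamino, or a carboxylic acid at this place would give a lower or a higher number than ethoxy or cyano. They also leave open whether the same change would give a step of similar size on a different core.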